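The source may report more compounds than this note shows. Statements on the series, on what has been measured and on what is new or still open speak of the compounds shown alone.

Of the compounds shown here, three have so far been measured in a functional assay on M21 cells (Homo sapiens) for antiproliferative activity, read by sulforhodamine B assay, with a stated time of 48 h; on this read-out lower numbers stand for stronger inhibition and higher numbers for weaker inhibition.

Compound 1, `CC(C)C(=O)Nc1cccc(S(=O)(=O)Oc2ccccc2C(C)C)c1`, gives 17000 nM.
Compound 2, `CCCCCC(=O)Nc1ccc(S(=O)(=O)Oc2ccccc2C(C)C)cc1`, gives 6700 nM.
Compound 3, `CCCCCC(=O)Nc1ccc(S(=O)(=O)Oc2ccccc2I)cc1`, gives 11000 nM.

Among these, compound 3 holds the second highest number of the three. Its nearest neighbour is compound 1 and its furthest is compound 2, yet both gaps lie within the scatter of the method, so the three compounds cannot really be told apart. Among the measured compounds shown here, the only single-point step among them, a 1.6-fold higher number from compound 2 to compound 3 (0.22 log units; within the scatter), is likewise within the scatter.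

Compound 4, `CCCNC(=O)Nc1ccc(S(=O)(=O)Oc2ccccc2I)cc1`, is the next compound to be measured. It differs from compound 3 by propylamino in place of pentyl on a carbonyl carbon. For the measured compounds named here, this change sits on the carbonyl carbon, a place that none of the measured steps touch: the step from compound 2 to compound 3 concerns a group on an aromatic carbon and so says nothing about what an exchange at the carbonyl does. Going by the values given here, with no step bearing on it, the estimate for compound 4 in this assay is 12000 nM, between 4000 nM and 40000 nM. As a step this means an expected 1.1-fold higher number from compound 3 to compound 4 (0.04 log units; within the scatter), not beyond the scatter.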

Compound 4, half-maximal inhibitory concentration: 5400 nM
Beside the measured number, compound 4's estimate is 2.2-fold (0.35 log units) above it; measured number inside the range.
By their numbers in this assay, from the lowest: compounds 4, 2, 3 and 1 (each within the scatter of the next, the first and the last beyond it).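

In this assay, replacing pentyl with propylamino on the carbonyl carbon gives a 2.0-fold lower number from compound 3 to compound 4 (0.31 log units; beyond the scatter), a modest step, but the first among these compounds to lie beyond the scatter, so this carbonyl carbon is a place where a change can shift the number, whereas the earlier step on an aromatic carbon stayed within the scatter. The exchange alters two things at once, bringing in a nitrogen with its hydrogen-bond donor and shortening the carbon chain, so the step cannot be assigned to either one. No measured evidence accounts for the difference.

As far as these compounds go, whether the nitrogen or the chain length matters more remains open. A butyl group or a pentylamino group on the same carbonyl carbon would help to separate the two.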